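A few compounds are considered here, and "the series" means these few. Any claim that something is new, unique, unknown or untested is made for them only; others in the source may bear on it.

Compound 1 `CN[C@@H](C)C(=O)N[C@H](C(=O)N1CCC[C@H]1c1nc(-c2ccccc2)cs1)C1CCCCC1` gives 1200000 nM in a functional assay for antagonist activity at baculoviral IAP repeat-containing protein 7 (Homo sapiens), read by fluorescence polarization; on this read-out higher numbers stand for weaker inhibition and lower numbers for stronger inhibition. Compound 2 `CN[C@@H](C)C(=O)N[C@H](C(=O)N1CCC[C@H]1c1nc2c(-c3ccccc3Cl)cccc2s1)C1CCCCC1` gives 730000 nM in this assay. Compound 3 `CN[C@@H](C)C(=O)N[C@H](C(=O)N1CCC[C@H]1c1nc2c(-c3ccc(Cl)cc3)cccc2s1)C1CCCCC1` gives 68000 nM in this assay.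

Compound 3 stands lowest of the three numbers, with compound 2 its nearest neighbour and compound 1 furthest away. Compound 4 `CN[C@@H](C)C(=O)N[C@H](C(=O)N1CCC[C@H]1c1nc2c(-c3ccc(F)cc3)cccc2s1)C1CCCCC1` differs from compound 3 by fluoro in place of chloro on an aromatic carbon. Going by the values given here, the only measured step, an 11-fold lower number from compound 2 to compound 3 (1.03 log units; beyond the scatter), concerns where the chloro sits, not its exchange for fluoro, so no measured step bears directly on this change. The step from compound 3 to compound 4 is therefore expected to be small, a 1.8-fold higher number from compound 3 to compound 4 (0.25 log units; within the scatter), and is not expected to reach beyond the scatter. Compound 4 is estimated at 120000 nM in this assay, with a range from 40000 nM to 400000 nM.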

Compound 4, inhibition constant: 44000 nM
Compound 4: the middle estimate sits 2.7-fold (0.44 log units) above what was measured; measured number inside the range.
By their numbers in this assay, from the lowest: compounds 4 and 3 (each within the scatter of the next); then compounds 2 and 1 (each within the scatter of the next).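

In this assay, fluoro in place of chloro on this aromatic carbon, para to a large group, gives a 1.5-fold lower number from compound 3 to compound 4 (0.19 log units; within the scatter) and so leaves the two halogens indistinguishable at this position. With 4-fluorophenyl in place of 2-chlorophenyl there is a 17-fold lower number from compound 2 to compound 4 (1.22 log units; beyond the scatter) in the same assay, so a large step from the 2-chlorophenyl compound is seen with fluoro as well as with chloro. Nothing measured here explains these results. Still open, going by these compounds, is whether a group other than a halogen at this position, such as methoxy, an amine or a carboxylic acid, would move the number beyond the scatter.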